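Nitro to amino with the acyl group kept

The source may report more compounds than this note shows. Statements on the series, on what has been measured and on what is new or still open speak of the compounds shown alone.

Measured in a functional assay on MGC-803 cells (Homo sapiens) for inhibition, read by MTT assay, with a stated time of 48 h; a higher number here means a weaker inhibitor, a lower number a stronger inhibitor:
compound 1 `C/C=C/C(=O)N(Cc1ccc(OC)c([N+](=O)[O-])c1)c1cc(OC)c(OC)c(OC)c1`: 590 nM
compound 2 `COc1ccc(CNc2cc(OC)c(OC)c(OC)c2)cc1[N+](=O)[O-]`: 19400 nM
compound 3 `COC(=O)c1cc(CNc2cc(OC)c(OC)c(OC)c2)ccc1OC`: 49600 nM

Of these three, compound 1 has the lowest number, at 590 nM. The next compound, not yet measured, is compound 4 `C/C=C/C(=O)N(Cc1ccc(OC)c(N)c1)c1cc(OC)c(OC)c(OC)c1`. It differs from compound 1 in one place: amino in place of nitro on an aromatic carbon. The new amino group sits ortho to a methoxy group.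

Among the measured compounds shown here, two measured steps bear on this change. The large one, a 33-fold higher number from compound 1 to compound 2 (1.52 log units; beyond the scatter), comes with hydrogen in place of (prop-1-en-1-yl)carbonyl on a nitrogen. Compound 4 keeps that group, so its number is expected to stay nearer that of compound 1 than those of the two compounds without it. For the measured compounds named here, the other step, a 2.6-fold higher number from compound 2 to compound 3 (0.41 log units; beyond the scatter), is modest and is the only measured change at the nitro-bearing carbon, with methoxycarbonyl in place of nitro. Going by the values given here, no amino compound has been measured, so the data do not set the direction, and a lean towards a lower number is only a judgement. The estimated step is a 3.0-fold lower number from compound 1 to compound 4 (0.47 log units; beyond the scatter), modest in size and expected with wide uncertainty. In this assay, compound 4 is expected at 200 nM, with an estimated range from 30 nM to 1200 nM.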

Compound 4, half-maximal inhibitory concentration: 150 nM
Beside the measured number, compound 4's estimate is 1.3-fold (0.12 log units) above it, and the stated range covers the measured number.
By their numbers in this assay, from the lowest: compound 4; then compound 1; then compound 2; then compound 3.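

In this assay, the nitro group is not needed for activity at this aromatic carbon: with the (prop-1-en-1-yl)carbonyl group kept, amino in place of nitro gives a 3.9-fold lower number from compound 1 to compound 4 (0.59 log units; beyond the scatter), and compound 4 has the lowest number of the four compounds. Among the compounds shown here, the only earlier change at this carbon, methoxycarbonyl in place of nitro, gave a 2.6-fold higher number from compound 2 to compound 3 (0.41 log units; beyond the scatter), but it was read on compounds without the acyl group and moved the number the other way, so the new step is the first reading of this position with the acyl group in place. Nothing measured on these compounds explains why the number falls with this change.

On these data alone, it remains open whether amino in place of nitro would lower the number to a similar extent in compound 2, which lacks the acyl group, so any dependence of the step on that group cannot yet be judged. As far as these compounds go, it is also open how a hydroxy group, a dimethylamino group or an acetylamino group at the same carbon, ortho to a methoxy group, would compare with the amino group of compound 4.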